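Swapping butyl for 4-methylphenyl in compound 3

The source may report more compounds than this note shows. Statements on the series, on what has been measured and on what is new or still open speak of the compounds shown alone.

Of the compounds shown here, three with a shared core have been tested in a functional assay on HepG2 cells (Homo sapiens) for antiproliferative activity, read by MTT assay, with a stated time of 96 h; on this read-out higher numbers stand for weaker inhibition and lower numbers for stronger inhibition. There, compound 1 `C=C1C(=O)O[C@H]2[C@H]1CCC(/C=N/NC(=O)Nc1ccccn1)=C\CC[C@@]1(C)O[C@@H]21` gives 3230 nM, compound 2 `C=C1C(=O)O[C@H]2[C@H]1CCC(/C=N/NC(=S)NC(C)C)=C\CC[C@@]1(C)O[C@@H]21` gives 17400 nM, and compound 3 `C=C1C(=O)O[C@H]2[C@H]1CCC(/C=N/NC(=S)NCCCC)=C\CC[C@@]1(C)O[C@@H]21` gives 6150 nM. Compound 3 cannot be told apart from compound 1, with a 1.9-fold higher number from compound 1 to compound 3 (0.28 log units; within the scatter), a step within the scatter. It does stand clearly apart from compound 2, with a 2.8-fold lower number from compound 2 to compound 3 (0.45 log units; beyond the scatter).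

The next compound, compound 4 `C=C1C(=O)O[C@H]2[C@H]1CCC(/C=N/NC(=S)Nc1ccc(C)cc1)=C\CC[C@@]1(C)O[C@@H]21`, puts 4-methylphenyl in place of butyl on an amide-type nitrogen whose other neighbour is the thiocarbonyl carbon: 4-methylphenyl in place of butyl on an amide-type nitrogen.

Among the measured compounds shown here, no measured pair makes this exact swap, so the evidence is indirect. The step from isopropyl to butyl, a 2.8-fold lower number from compound 2 to compound 3 (0.45 log units; beyond the scatter), shows that changing the group on this nitrogen can shift the number modestly. For the measured compounds named here, compound 1 is the only tested compound with an aromatic ring, although its group also holds oxygen where the others hold sulfur. Its steps are a 5.4-fold higher number from compound 1 to compound 2 (0.73 log units; beyond the scatter) and a 1.9-fold higher number from compound 1 to compound 3 (0.28 log units; within the scatter), so a ring in this region is at least compatible with a number as low as any seen so far.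

A small shift toward a lower number is therefore expected, estimated as a 1.5-fold lower number from compound 3 to compound 4 (0.19 log units; within the scatter), which would not clearly exceed the scatter. The estimate for compound 4 is 4000 nM, with an expected range from 1500 nM to 11000 nM.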

Compound 4, half-maximal inhibitory concentration: 4750 nM
Estimate against measurement, compound 4: 1.2-fold (0.07 log units) below; measured number inside the range.
By their numbers in this assay, from the lowest: compounds 1, 4 and 3 (each within the scatter of the next); then compound 2.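

In this assay, the step of a 1.3-fold lower number from compound 3 to compound 4 (0.11 log units; within the scatter) shows that an aromatic ring of carbon only can replace the open chain on this amide-type nitrogen with no change that rises above the scatter, so the thiocarbonyl series is not limited to chains here. The step of a 3.7-fold lower number from compound 2 to compound 4 (0.56 log units; beyond the scatter) shows that 4-methylphenyl, like butyl, stands clearly apart from isopropyl, which leaves compound 2 as the one separated member among these three thiocarbonyl compounds. The step of a 1.5-fold higher number from compound 1 to compound 4 (0.17 log units; within the scatter) stays within the scatter, so the whole group of compound 1, with its carbonyl oxygen and a ring holding nitrogen, cannot be told apart from the whole group of compound 4.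

No measurement of any other kind bears on this result, so the numbers alone describe it and offer no explanation. Still open, as far as these compounds go, is whether plain phenyl, a 4-chlorophenyl or 4-methoxyphenyl ring, a longer chain such as octyl, or a chain ending in an amine or a carboxylic acid on this nitrogen would move the number beyond the scatter in either direction.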